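Swapping the aryl group of a quinoline urea

A few compounds are considered here, and "the series" means these few. Any claim that something is new, unique, unknown or untested is made for them only; others in the source may bear on it.

Measured so far:
compound 1 `Cc1cc(NC(=O)Nc2cccc(F)c2)c2ccccc2n1` — > 25000 nM
compound 2 `Cc1cc(NC(=O)Nc2cccc(OC(F)(F)F)c2)c2ccccc2n1` — 22000 nM

Compound 1 was tested in an ADME assay on HEK293 cells (Homo sapiens) for cytotoxicity, with a stated time of 72 h; a higher number here means that more compound is needed for the effect, a lower number that less compound is needed. There compound 1 gives only a limit, > 25000 nM, so its position is known only as a floor, not as a number (the limit of > 25000 nM in this assay, at which 1 of the 2 values shown sits). Compound 2 differs from it in a single place, trifluoromethoxy in place of fluoro on an aromatic carbon, and in this assay compound 2 gives 22000 nM; the step of an at least 1.1-fold lower number from compound 1 to compound 2 (0.05 log units; that floor lies within the scatter) is small.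

Compound 3 `Cc1cc(NC(=O)Nc2ccc(Cl)cc2)c2ccccc2n1` is not yet measured. It differs from compound 1 as follows: 4-chlorophenyl in place of 3-fluorophenyl on an amide-type nitrogen. Among the compounds with values here, no measured step involves this same change; the only measured step, from fluoro to trifluoromethoxy, stayed at or near the limit. For compound 3 a step of about a number no higher from compound 1 to compound 3 (the limit leaves the size open) is therefore expected, that is no change beyond the scatter. Compound 3 is estimated at 25000 nM in this assay, within 12000 nM to 60000 nM.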

Compound 3, half-maximal effective concentration: > 25000 nM
Compound 3 ended at the assay's limit; the forecaster's own chance of this, stated with the estimate: 60%; the middle value sits exactly at the limit.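

In this assay compound 3 gives > 25000 nM as a limit of the assay, not a number. Compound 1 also gives a limit, and the step between compound 1 and compound 3 cannot be read. The compounds shown leave open whether 4-chlorophenyl in place of 3-fluorophenyl changes the number at all.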